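Ribose-bearing purinone analogues: a substituent swap at the chain carbon

The source may hold more compounds than are shown below. What is called first, only, known or untested is meant among the compounds shown, and "the series" means these compounds.

The series rests on a shared core carrying a sugar and a variable chain on the other ring nitrogen. Compound 1 `NCC(O)Cn1c(=O)n(C2OC(CO)[C@@H](O)[C@H]2O)c2nc(N)nc(O)c21` is the reference point; in a functional assay (B cells) with Mus musculus as the target (a higher number here means that more compound is needed for the effect, a lower number that less compound is needed), compound 1 gives 28 uM. Compound 2 `C=CCn1c(=S)n(COCCO)c2nc(N)nc(O)c21` differs from it in more than one place, and in this assay compound 2 gives 14 uM. Within the data shown here, the values of compound 1 and compound 2 sit within the usual scatter of each other, so no order between them can be read from the two numbers, and no single-point step between measured compounds is available in this set.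

Compound 3 `N#Cc1cccc(Cn2c(=O)n(C3OC(CO)[C@@H](O)[C@H]3O)c3nc(N)nc(O)c32)c1` is not yet measured. It differs from compound 1 as follows: 3-cyanophenyl in place of 2-amino-1-hydroxyethyl on a saturated chain carbon bound to an aromatic nitrogen. Among the measured compounds shown here, no measured pair isolates this kind of change, so the direction cannot be drawn from the data; only the size of what is usually seen for such a swap can be guessed at. The expected step in this assay from compound 1 to compound 3 is a 1.9-fold lower number from compound 1 to compound 3 (0.27 log units; within the scatter), a modest shift of uncertain sign. For compound 3 the estimate in this assay is 15 uM, with a range from 4 uM to 60 uM.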

Compound 3, concentration for half-maximal effect: 3 uM
The estimate for compound 3 lay 5.0-fold (0.70 log units) above the measured number; the whole stated range lies above it.
By their numbers in this assay, from the lowest: compound 3; then compounds 2 and 1 (each within the scatter of the next).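

The step from 3-amino-2-hydroxypropyl to 3-cyanobenzyl gives the series its first change at a single place that can be read: in this assay it is a 9.3-fold lower number from compound 1 to compound 3 (0.97 log units; beyond the scatter), with the sugar and the rest of the shared core unchanged. This position, on a saturated chain carbon bound to an aromatic nitrogen, therefore tolerates a larger group with a six-membered aromatic ring and a nitrile, and the effect needs less compound. The hydrogen-bond donors of 2-amino-1-hydroxyethyl are absent from 3-cyanophenyl, so in this pair they are not required for the effect, although no measured evidence bears on the origin of the step.

Among these compounds, the single step changes the ring, the nitrile and the amino and hydroxyl groups together, so the contribution of each cannot be separated. On these data alone, whether plain benzyl would retain the lower number, or whether a carboxylic acid or an amine could stand in place of the nitrile on the ring, remains open.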